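The source may hold more compounds than are shown below. What is called first, only, known or untested is meant among the compounds shown, and "the series" means these compounds.

In a functional assay on CCRF-CEM/VCR-1000 cells (Homo sapiens) for inhibition (a higher number here means a weaker inhibitor, a lower number a stronger inhibitor), compound 3 `CC(=O)c1cccc(OCC(O)CN2CCCCC2)c1` gives 9070 nM, the highest of the three numbers and, with both steps to the other compounds beyond the scatter, the weakest inhibitor of the set. Compound 1 `OC(COc1ccccc1C(O)CCc1ccccc1)CN1CCCCC1` gives 1340 nM and compound 2 `COC(CCc1ccccc1)c1ccccc1OCC(O)CN1CCCCC1` gives 770 nM; both carry a longer, phenethyl-bearing side chain on the shared core where compound 3 carries only a short acetyl group. Within the data shown here, the one measured step, a 1.7-fold lower number from compound 1 to compound 2 (0.24 log units; within the scatter), swaps a hydroxyl for a methoxy on that side chain and barely moves the number. Compound 4 `O=C(CCc1ccccc1)c1cccc(OCC(O)CN2CCCCC2)c1` is compound 3 with benzyl in place of hydrogen on a saturated chain carbon bound to a carbonyl carbon; the same difference cut one bond further out reads methyl to phenethyl, so compound 4 comes to resemble compounds 1 and 2 in chain length. Among the measured compounds shown here, no measured step adds a benzyl, so the expectation rests on the gap between compound 3 and the two longer-chain compounds. Compound 1 gives 1340 nM and compound 2 gives 770 nM, both well below compound 3 at 9070 nM. The number for compound 4 is therefore expected to fall by roughly a 4.5-fold lower number from compound 3 to compound 4 (0.66 log units; beyond the scatter). Compound 4 is estimated at 2000 nM, within a range of 700 nM to 5500 nM.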

Compound 4, half-maximal inhibitory concentration: 390 nM
Estimate against measurement, compound 4: 5.1-fold (0.71 log units) above; the measured number lies below the stated range.
By their numbers in this assay, from the lowest: compounds 4, 2 and 1 (each within the scatter of the next, the first and the last beyond it); then compound 3.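

In this assay, among these compounds, putting benzyl in place of hydrogen on a saturated chain carbon bound to a carbonyl carbon gives a 23-fold lower number from compound 3 to compound 4 (1.37 log units; beyond the scatter) and is the first measured change in this set to reach beyond the scatter. This position therefore accepts a much larger group, one that brings a six-membered aromatic ring of carbon only, and inhibition improves strongly; the earlier swap of a hydroxyl for a methoxy could not show this, since its step stayed within the scatter. Nothing at hand explains the size of this gain.

Going by these compounds, whether the aromatic ring is needed remains open, and a cyclohexylmethyl group at the same carbon would test that. How much of the gain a plain methyl or a longer chain ending in phenyl would keep is also unknown.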